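Swapping the thiophene for isobutyl on the shared core

The source may report more compounds than this note shows. Statements on the series, on what has been measured and on what is new or still open speak of the compounds shown alone.

Measured compounds and their values:
compound 1 `O=C(O)c1cccc(Cc2c(-c3ccccc3)nn3ccccc23)n1` gives 2300 nM;
compound 2 `O=C(O)c1cccc(Cc2c(-c3ccccc3)nn3cc(C4CC4)ccc23)n1` gives 190 nM;
compound 3 `O=C(O)c1cccc(Cc2c(-c3ccsc3)nn3cc(Cl)ccc23)n1` gives 110 nM.

In a functional assay on cells for antagonist activity at prostaglandin E2 receptor EP1 subtype (Rattus norvegicus), read by fluorescence and calcium flux, with a stated time of 60 s (a lower number here means a stronger inhibitor, a higher number a weaker inhibitor), compound 3 gives 110 nM, well below compound 1 and close to compound 2. Within the data shown here, the only measured step, a 12-fold lower number from compound 1 to compound 2 (1.08 log units; beyond the scatter), shows the cyclopropyl addition at a different position. Compound 4 `CC(C)Cc1nn2cc(Cl)ccc2c1Cc1cccc(C(=O)O)n1` instead carries the change (isobutyl in place of thiophen-3-yl on an aromatic carbon). Among the measured compounds shown here, no measured pair shows a thiophen-3-yl replaced by isobutyl, so there is nothing to lean on; a modest weakening is expected, a 3.2-fold higher number from compound 3 to compound 4 (0.50 log units; beyond the scatter), with wide uncertainty. For compound 4 the expected value in this assay is 350 nM, between 80 nM and 1500 nM.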

Compound 4, half-maximal inhibitory concentration: 200 nM
The estimate for compound 4 lay 1.8-fold (0.24 log units) above the measured number, and the stated range covers the measured number.
By their numbers in this assay, from the lowest: compounds 3, 2 and 4 (each within the scatter of the next); then compound 1.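

In this assay, replacing the ring with the open chain gives a 1.8-fold higher number from compound 3 to compound 4 (0.26 log units; within the scatter), so the change cannot be told apart from repeat-measurement noise. In this pair, then, the aromatic carbon next to the ring nitrogen does not need an aromatic ring or its sulfur: isobutyl, with no ring and no hydrogen-bond acceptor, serves as well. Nothing available explains why these two groups read alike. Still open, as far as these compounds go, is how a longer chain, an amine or a carboxylic acid would fare here. Whether isobutyl would match the ring on a core bearing a different group in place of the chlorine is also unknown.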